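Swapping an Ether for a Plain Alkyl Chain

The source may hold more compounds than are shown below. What is called first, only, known or untested is meant among the compounds shown, and "the series" means these compounds.

Measured so far:
- Compound 1, `CCOc1ncc(-c2nc(C(F)(F)F)sc2N2CCN(C(=O)Cn3nc(C)nc3C)[C@H](C)C2)cn1`: 7 nM
- Compound 2, `Cc1nc(C)n(CC(=O)N2CCN(c3sc(C(F)(F)F)nc3-c3cnc(OC4CCC4)nc3)C[C@H]2C)n1`: 4 nM

Both compounds were tested in a functional assay on CHO-K1 cells for antagonist activity at C-X-C chemokine receptor type 3 (Homo sapiens), read by FLIPR, with a stated time of 10 min; a higher number here means a weaker inhibitor, a lower number a stronger inhibitor. Compound 2 gives 4 nM, and compound 1 sits within the scatter of that value, so the two cannot be told apart on these numbers alone. Among the measured compounds shown here, the single measured step, a 1.8-fold lower number from compound 1 to compound 2 (0.24 log units; within the scatter), shows that enlarging the group on the oxygen from ethyl to cyclobutyl changed nothing that the assay can resolve.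

Compound 3, `CCc1ncc(-c2nc(C(F)(F)F)sc2N2CCN(C(=O)Cn3nc(C)nc3C)[C@H](C)C2)cn1`, is the next compound. Its difference from compound 2 is ethyl in place of cyclobutyloxy on an aromatic carbon, that is, on the carbon between two ring nitrogen atoms the cyclobutyloxy group is replaced by ethyl. For the measured compounds named here, no measured pair covers the loss of the oxygen itself, so the only guide is that the one step at this position, from compound 1 to compound 2, stayed within the scatter. The change to compound 3 is expected to be modest as well, with the step of a 2.5-fold higher number from compound 2 to compound 3 (0.40 log units; beyond the scatter) leaning only slightly toward a weaker compound. Compound 3 is therefore estimated at 10 nM, within 3 nM to 35 nM.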

Compound 3, half-maximal inhibitory concentration: 14 nM
Compound 3: middle estimate off by 1.4-fold (0.15 log units), on the low side; measured number inside the range.
By their numbers in this assay, from the lowest: compounds 2, 1 and 3 (each within the scatter of the next, the first and the last beyond it).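

Among the compounds shown here, this is the first change at this position that removes the oxygen, and in this assay going from cyclobutyloxy to ethyl gives a 3.5-fold higher number from compound 2 to compound 3 (0.54 log units; beyond the scatter), the first step here to clear the scatter. That swap alters two things at once, since the four-membered ring leaves along with the oxygen, whereas the swap of ethoxy for ethyl takes away only the oxygen and gives a 2.0-fold higher number from compound 1 to compound 3 (0.30 log units; within the scatter), so on these numbers the oxygen alone has no effect that can be resolved. No supporting measurement bears on either step, so the numbers record what happened without explaining it.

The compounds shown leave open how much of the larger step belongs to the four-membered ring and how much to the oxygen, a question that cyclobutyl joined directly to the same aromatic carbon would help to separate. Also open, on these data alone, is how this position responds to groups of another kind, such as an amine or a longer chain like butyl.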